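The compounds below may be only part of what the source reports. "The series", "measured", "known", "first", "only" and "open" are said of these compounds alone.

Compound 1 `CC1CC/C(=N\Nc2ccccc2Cl)c2ncc(C(=O)O)c(=O)n21` — > 1000 umol/kg
Compound 2 `CCOc1ccccc1N/N=C1\CCC(C)n2c1ncc(C(=O)O)c2=O` — > 1000 umol/kg

In a functional assay on the whole organism for inhibition, with Rattus norvegicus as the target (on this read-out higher numbers stand for an effect only at larger amounts of compound and lower numbers for an effect already at smaller amounts), compound 1 gives > 1000 umol/kg, which is a limit of the assay rather than a number. In this assay compound 2 likewise gives > 1000 umol/kg, again only a limit. Both measurements sit at the limit of > 1000 umol/kg in this assay, at which 2 of the 2 values shown sit, so compound 2 stands at the limit and nowhere more precise. Among the measured compounds shown here, the single measured step is a step that the two limits leave unreadable from compound 1 to compound 2, and its size cannot be read.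

Compound 3 `CC1CC/C(=N\Nc2ccccc2C(F)(F)F)c2ncc(C(=O)O)c(=O)n21` differs from compound 2 by trifluoromethyl in place of ethoxy on an aromatic carbon. For the measured compounds named here, no measured step bears on this change, and the one step available yields no size in either direction. Compound 3 is therefore expected to show no step beyond the scatter, a step that the limit leaves unreadable from compound 2 to compound 3, with the most likely outcome again a limit. The estimate for compound 3 is 2000 umol/kg, with a range from 700 umol/kg to 6000 umol/kg.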

Compound 3, dose for 50% inhibition: > 1000 umol/kg
Compound 3: only a limit was reported (the forecaster's own chance of this, stated with the estimate: 80%); the middle value does not contradict the limit.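

In this assay compound 3 gives > 1000 umol/kg, which is a limit of the assay and not a number. No step among compound 1, compound 2 and compound 3 can be read: the limit of > 1000 umol/kg in this assay, at which 3 of the 3 values shown sit.

The compounds shown leave open how the chloro, ethoxy and trifluoromethyl compounds rank against one another.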